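Swapping one five-membered ring for another on the shared core

The source may report more compounds than this note shows. Statements on the series, on what has been measured and on what is new or still open speak of the compounds shown alone.

Compound 1 `O=C1NC(=S)S/C1=C\c1ccccc1OCc1ccccc1`: 13000 nM
Compound 2 `O=C1NC(=S)S/C1=C\c1cc([N+](=O)[O-])ccc1OCc1ccccc1`: 5000 nM

In a functional assay on A549 cells (Homo sapiens) for inhibition, read by sulforhodamine B assay (a lower number here means a stronger inhibitor of growth, a higher number a weaker inhibitor of growth), compound 2 gives the lowest of the two numbers; its nearest neighbour is compound 1, and the step of a 2.6-fold lower number from compound 1 to compound 2 (0.41 log units; beyond the scatter) came with nitro in place of hydrogen on an aromatic carbon. Compound 3 `O=C1NC(=O)/C(=C/c2cc([N+](=O)[O-])ccc2OCc2ccccc2)S1` differs from compound 2 by a group of 8 heavy atoms (4 carbon, 1 nitrogen, 2 oxygen, 1 sulfur; one five-membered non-aromatic ring with 2 hetero atoms) in place of a group of 8 heavy atoms (4 carbon, 1 nitrogen, 1 oxygen, 2 sulfur; one five-membered non-aromatic ring with 2 hetero atoms), on an aromatic carbon. Among the compounds with values here, no measured step bears on this exchange of one ring for another; the only known step concerns the nitro group. Compound 3 is therefore expected to sit close to compound 2, with a 1.6-fold higher number from compound 2 to compound 3 (0.20 log units; within the scatter) as a cautious estimate, giving 8000 nM within 3000 nM to 25000 nM.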

Compound 3, concentration for 50% growth inhibition: 14000 nM
Beside the measured number, compound 3's estimate is 1.8-fold (0.24 log units) below it, and the stated range covers the measured number.
By their numbers in this assay, from the lowest: compound 2; then compounds 1 and 3 (each within the scatter of the next).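

In this assay, the ring on this aromatic carbon, ortho to a benzyloxy group, proves to matter as well as the nitro group: exchanging it gives a 2.8-fold higher number from compound 2 to compound 3 (0.45 log units; beyond the scatter). The two rings have the same heavy-atom count and the same hydrogen-bond donor and acceptor counts, differing in one sulfur exchanged for one oxygen, so these counts alone do not settle the number. Nothing measured here accounts for this step. The compounds shown leave open whether the ring exchange gives a similar step without the nitro group. They also leave open how an amine or a carboxylic acid in the nitro group's place would read.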